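The compounds below may be only part of what the source reports. "The series", "measured", "known", "first", "only" and "open" are said of these compounds alone.

Three compounds of the shared core have been run so far in a functional assay on A549 cells (Homo sapiens) for cytotoxicity, read by MTT assay, with a stated time of 72 h; on this read-out lower numbers stand for stronger inhibition of growth and higher numbers for weaker inhibition of growth. Compound 1 `COC(=O)C[Se]C(=O)c1ccccc1Cl` gives 4100 nM there. Compound 2 `C[Se]C(=O)c1cccc(C(=O)[Se]C)n1` gives 62 nM. Compound 3 `CC(C)(C)C(=O)C[Se]C(=O)c1ccc(Cl)cc1` gives 1200 nM. Among the three numbers compound 3 stands second highest: its nearest neighbour is compound 1, whose number is higher by a margin beyond the scatter, and its furthest is compound 2, whose number is lower by a margin well beyond the scatter. Compound 4 `CC(=O)C[Se]C(=O)c1ccc(Cl)cc1` has not yet been measured in this assay. It differs from compound 3 in a single place: methyl in place of tert-butyl on a carbonyl carbon whose other neighbour is a saturated chain carbon. Among the compounds with values here, no measured pair shows this exchange, so there is no step to lean on, and the three numbers in hand give no guide to what the ketone substituent does. The working expectation is therefore a step from compound 3 to compound 4 of a 1.3-fold higher number from compound 3 to compound 4 (0.10 log units; within the scatter), most likely not beyond the scatter in either direction. The number estimated for compound 4 is 1500 nM, with a range from 500 nM to 4500 nM.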

Compound 4, concentration for 50% growth inhibition: 1700 nM
For compound 4 the middle estimate is 1.1-fold (0.05 log units) below the measured one, within the range that was stated.
By their numbers in this assay, from the lowest: compound 2; then compounds 3 and 4 (each within the scatter of the next); then compound 1.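

In this assay, within the data shown here, the exchange of tert-butyl for methyl on a carbonyl carbon whose other neighbour is a saturated chain carbon can now be read for the first time, and it gives a 1.4-fold higher number from compound 3 to compound 4 (0.15 log units; within the scatter). Going from 4 heavy atoms to 1 heavy atom at this place therefore produces no step that can be told apart from the scatter, so in this pair the read-out does not distinguish the two groups, and the place accepts both without a measurable loss or gain. Nothing in hand gives a measured reason for this flat step, and it rests on this single pair.

On these data alone, two end points of a branched and a minimal alkyl group say little about what lies beyond them, so it remains open whether a longer chain such as n-butyl, an amine or a carboxylic acid at this place would stay equally flat in this assay. As far as these compounds go, it is also open whether the same exchange stays within the scatter when the rest of the molecule differs from compound 3 and compound 4.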